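Working Notes on the Step from Compound 2 to Compound 4

The source may report more compounds than this note shows. Statements on the series, on what has been measured and on what is new or still open speak of the compounds shown alone.

Measured compounds:
Compound 1, `COc1cc(C(=O)O)ccc1OCCCCOc1ccc(C(=O)C(C)C)c(O)c1C`: 113 nM
Compound 2, `Cc1c(OCCCCOc2ccc(C(=O)O)cc2F)ccc(C(=O)CC2CCCC2)c1O`: 639 nM
Compound 3, `Cc1c(OCCCCOc2ccc(C(=O)O)cc2F)ccc(C(=O)CC(C)C)c1O`: 102 nM

All three values come from an assay on HEK293 cells for positive allosteric modulation of metabotropic glutamate receptor 2 (Rattus norvegicus), read by thallium flux, with a stated time of 2.5 min; on this read-out higher numbers stand for an effect only at larger amounts of compound and lower numbers for an effect already at smaller amounts. Compound 2 gives the highest number of the three; compound 1 and compound 3 both stand lower, each beyond the scatter.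

Compound 4, `Cc1c(OCCCCOc2ccc(F)c(C(=O)O)c2)ccc(C(=O)CC2CCCC2)c1O`, has not yet been measured. It differs from compound 2 as follows:
3-carboxy-4-fluorophenyl in place of 4-carboxy-2-fluorophenyl on an oxygen on a saturated carbon

Going by the values given here, the only measured step, a 6.3-fold lower number from compound 2 to compound 3 (0.80 log units; beyond the scatter), alters the chain on the carbonyl side and leaves the aryl acid unchanged, so it does not bear on the present change. Among the compounds with values here, no measured pair shows the exchange of the carboxy and fluorine positions on the aryl acid, so nothing anchors a direction. The expected step of a 1.1-fold higher number from compound 2 to compound 4 (0.04 log units; within the scatter) is therefore none beyond the scatter, with a wide range to reflect the absence of a precedent. Compound 4 is estimated at 700 nM in this assay , between 200 nM and 2500 nM.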

Compound 4, half-maximal effective concentration: 699 nM
The estimate for compound 4 lay 1.0-fold (0.00 log units) above the measured number, and the stated range covers the measured number.
By their numbers in this assay, from the lowest: compounds 3 and 1 (each within the scatter of the next); then compounds 2 and 4 (each within the scatter of the next).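

In this assay, 3-carboxy-4-fluorophenyl in place of 4-carboxy-2-fluorophenyl on an oxygen on a saturated carbon gives a 1.1-fold higher number from compound 2 to compound 4 (0.04 log units; within the scatter), so with the cyclopentyl chain in place this exchange of isomeric aryl acids produces no resolvable change. Going by these compounds alone, this is the first view of this position with the rest of the structure held fixed, and it contrasts with the change on the carbonyl side, a 6.3-fold lower number from compound 2 to compound 3 (0.80 log units; beyond the scatter), which lies beyond the scatter. No measurement at hand accounts for the lack of a shift at this position.

Open, on these data alone, is whether the same exchange would also leave the number unmoved on the isopropyl chain of compound 3. Also open, as far as these compounds go, is how a primary amide or a tetrazole in place of the carboxy group would read in this assay.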